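The source may report more compounds than this note shows. Statements on the series, on what has been measured and on what is new or still open speak of the compounds shown alone.

Of the compounds shown here, three built on a shared core have been tested in a functional assay for inhibition, tested at 100 ug/mL; a lower number here means a weaker effect, a higher number a stronger effect of the compound at the concentration tested. Compound 1 `COc1ccc(-c2cc(-c3cc(C(C)C)c(O)cc3C)[nH]c(=O)c2C#N)c(OC)c1` gives 58% in this assay. Compound 2 `Cc1cc(O)c(C(C)C)cc1-c1cc(-c2ccco2)c(C#N)c(=O)[nH]1` gives 70% in this assay, and compound 3 `COc1cc(-c2cc(-c3cc(C(C)C)c(O)cc3C)[nH]c(=O)c2C#N)ccc1O` gives 44% in this assay. Among these three, compound 3 stands lowest: its nearest neighbour on the numbers is compound 1, which sits higher, and the step of a number 14 percentage points lower from compound 1 to compound 3 (beyond the scatter) is beyond the scatter, as is the step of a number 26 percentage points lower from compound 2 to compound 3 (beyond the scatter). The step of a number 12 percentage points higher from compound 1 to compound 2 (beyond the scatter) shows compound 2 highest of the three.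

Compound 4 `COc1ccc(-c2cc(-c3cc(C(C)C)c(O)cc3C)[nH]c(=O)c2C#N)cc1OC` has not yet been measured. It differs from compound 3 in one place: methyl in place of hydrogen on an oxygen on an aromatic ring.

Within the data shown here, the most relevant measured step is the one from compound 1 to compound 3, where a 2,4-dimethoxyphenyl was swapped for a 4-hydroxy-3-methoxyphenyl and the number fell by a number 14 percentage points lower from compound 1 to compound 3 (beyond the scatter). The change from compound 3 to compound 4 runs the other way, turning the hydroxy back into a methoxy, though on a 3,4-dimethoxyphenyl rather than a 2,4-dimethoxyphenyl. A modest rise is therefore expected, of about a number 10 percentage points higher from compound 3 to compound 4 (within the scatter). Compound 4 is estimated to give 54% in this assay, most likely between 40% and 68%.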

Compound 4, a percentage reported as inhibition, at one concentration (the size of the read-out at that concentration, not a potency): 61%
Compound 4: middle estimate off by 7 percentage points, on the low side; the measured number falls inside the stated range.
By their numbers in this assay, from the lowest: compound 3; then compounds 1, 4 and 2 (each within the scatter of the next, the first and the last beyond it).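

In this assay, among these compounds, adding one methyl to the hydroxy oxygen, which turns the 4-hydroxy-3-methoxyphenyl into a 3,4-dimethoxyphenyl, gives a number 17 percentage points higher from compound 3 to compound 4 (beyond the scatter) and is the only step here that changes nothing but that hydrogen, so this small edit at this position is enough to shift the read-out. With the oxygen capped, the two dimethoxyphenyl compounds cannot be told apart, with a number 3 percentage points higher from compound 1 to compound 4 (within the scatter) as the step between them, and the swap from furan-2-yl to 3,4-dimethoxyphenyl gives a number 9 percentage points lower from compound 2 to compound 4 (within the scatter), so among these four compounds only compound 3, with its free hydroxy, stands apart from the others. Nothing available explains why the free hydroxy goes with the lower number.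

The compounds shown leave open whether a longer chain on this oxygen, such as ethoxy or propoxy, would read like methoxy or would move the number further. An amine in place of the hydroxy would also test whether a hydrogen on this oxygen is what matters, or the oxygen itself.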